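Aryl substituent changes on a fluorinated bicyclic amino diacid series

The source may report more compounds than this note shows. Statements on the series, on what has been measured and on what is new or still open speak of the compounds shown alone.

Measured: compound 1 `N[C@]1(C(=O)O)[C@H]2[C@@H](C[C@H]1OCc1cccc(Br)c1)[C@]2(F)C(=O)O` 4.71 nM; compound 2 `N[C@]1(C(=O)O)[C@H]2[C@@H](C[C@H]1OCc1cccc(C(F)(F)F)c1)[C@]2(F)C(=O)O` 5.72 nM; compound 3 `N[C@]1(C(=O)O)[C@H]2[C@@H](C[C@H]1OCc1cccc([N+](=O)[O-])c1)[C@]2(F)C(=O)O` 7.87 nM. All values are from an assay on CHO cells for binding affinity to metabotropic glutamate receptor 2 (Rattus norvegicus); a lower number here means a stronger inhibitor, a higher number a weaker inhibitor.

Compound 1 sits at one end of the three numbers, but compound 2 and compound 3 both lie within scatter of it: a 1.2-fold higher number from compound 1 to compound 2 (0.08 log units; within the scatter), a 1.7-fold higher number from compound 1 to compound 3 (0.22 log units; within the scatter), and between them a 1.4-fold higher number from compound 2 to compound 3 (0.14 log units; within the scatter). Every change so far on the aromatic ring has left this assay essentially unmoved.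

Compound 4 `N[C@]1(C(=O)O)[C@H]2[C@@H](C[C@H]1OCc1cc(Cl)cc(Cl)c1)[C@]2(F)C(=O)O` carries 3,5-dichlorophenyl in place of 3-bromophenyl on a saturated chain carbon bound to an oxygen on a saturated carbon. Within the data shown here, no measured step covers a second halogen on that ring; the steps that bear on it are the swaps of the single substituent, all within scatter. A step of a 1.2-fold higher number from compound 1 to compound 4 (0.07 log units; within the scatter) is therefore expected, none beyond the scatter. Compound 4 is estimated at 5.5 nM in this assay, within 2.2 nM to 14 nM.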

Compound 4, inhibition constant: 5.61 nM
Beside the measured number, compound 4's estimate is 1.0-fold (0.01 log units) below it, within the range that was stated.
By their numbers in this assay, from the lowest: compounds 1, 4, 2 and 3 (each within the scatter of the next).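

With 3,5-dichlorophenyl in place of 3-bromophenyl, this assay gives a 1.2-fold higher number from compound 1 to compound 4 (0.08 log units; within the scatter). Earlier steps swapped only a single substituent on the aromatic ring, whereas this one shows that a ring with more than one substituent also stays within the scatter at this position on the saturated chain carbon bound to an oxygen. No available evidence bears on why the number holds.

Still open, from the compounds shown here alone, is whether an amine or a carboxylic acid on the aromatic ring would stay within the scatter of compound 1. The same question applies to a longer chain carrying that ring.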